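A few compounds are considered here, and "the series" means these few. Any claim that something is new, unique, unknown or untested is made for them only; others in the source may bear on it.

Series notes. Compound 1 `O=C1c2ccccc2C(=O)C1CC#CCN1CCCCC1` carries the shared core with an unsubstituted six-membered saturated amine ring; in a functional assay on ileum (Cavia porcellus) for inhibition, with a stated time of 15 min (a lower number here means tighter binding, a higher number weaker binding), compound 1 gives 1580 nM. Compound 2 `CC1CCCCN1CC#CCC1C(=O)c2ccccc2C1=O` adds one methyl on a saturated ring carbon of that ring, and in this assay compound 2 gives 1260 nM. Going by the values given here, of the two numbers so far, compound 2 holds the lower one, but the step of a 1.3-fold lower number from compound 1 to compound 2 (0.10 log units; within the scatter) lies within the scatter, so no order between compound 1 and compound 2 can be read from these two values.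

Compound 3 `CC1CCCC(C)N1CC#CCC1C(=O)c2ccccc2C1=O` is not yet measured. It differs from compound 2 by methyl in place of hydrogen on a saturated ring carbon. Among the compounds with values here, the only measured step bearing on this change is a 1.3-fold lower number from compound 1 to compound 2 (0.10 log units; within the scatter), which is a methyl in place of hydrogen on the same saturated ring and stayed within the scatter. On that basis the second methyl is expected to give no step beyond the scatter, so for compound 3 in this assay a value of 1100 nM is estimated, within 400 nM to 3200 nM. The expected step from compound 2 to compound 3 is thus a 1.1-fold lower number from compound 2 to compound 3 (0.06 log units; within the scatter).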

Compound 3, dissociation constant: 2000 nM
Beside the measured number, compound 3's estimate is 1.8-fold (0.26 log units) below it; measured number inside the range.
By their numbers in this assay, from the lowest: compounds 2, 1 and 3 (each within the scatter of the next).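

Working from this assay, the second methyl, on a saturated ring carbon next to the ring nitrogen and two ring bonds from the ring atom that bears a methyl group, gives a 1.6-fold higher number from compound 2 to compound 3 (0.20 log units; within the scatter) and so stays within the scatter even with the first methyl already on the ring. Going by these compounds alone, the earlier step, a 1.3-fold lower number from compound 1 to compound 2 (0.10 log units; within the scatter), showed only a single methyl on the ring; this result extends that reading to a ring bearing a methyl group on both carbons next to the nitrogen. No supporting evidence bears on this result.

From the compounds shown here alone, whether this carbon would give a step beyond the scatter with a group larger than methyl, such as ethyl or a longer chain, remains open. A hydroxyl or a carboxylic acid at the same carbon is equally unresolved by these compounds.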